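The source may hold more compounds than are shown below. What is called first, only, known or untested is meant among the compounds shown, and "the series" means these compounds.

Measured so far in a functional assay on K562 cells (Homo sapiens), read by MTT assay, with a stated time of 72 h; a lower number here means a stronger inhibitor, a higher number a weaker inhibitor:
compound 1 `Nc1nc(N)c2c(-c3cc4ccccc4o3)cn([C@@H]3O[C@H](CO)[C@@H](O)[C@H]3O)c2n1` gives 18600 nM
compound 2 `Cc1nc(N)c2c(-c3cc4ccccc4o3)cn([C@@H]3O[C@H](CO)[C@@H](O)[C@H]3O)c2n1` gives 15700 nM
compound 3 `CN(C)c1ncnc2c1c(-c1ccoc1)cn2[C@@H]1O[C@H](CO)[C@@H](O)[C@H]1O` gives 1540 nM

For the measured compounds named here, compound 2 stands second highest of the three numbers in this assay; its nearest neighbour is compound 1, and the only single-site step among the measured compounds, a 1.2-fold lower number from compound 1 to compound 2 (0.07 log units; within the scatter), lies within the scatter. Compound 3 sits well below both, but it differs from compound 2 in more than one place, so its value alone cannot be read as the effect of any one change.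

Compound 4 `Cc1nc(N)c2c(-c3ccco3)cn([C@@H]3O[C@H](CO)[C@@H](O)[C@H]3O)c2n1` carries the change (furan-2-yl in place of 1-benzofuran-2-yl on an aromatic carbon). Going by the values given here, no measured step covers this change: the step from compound 1 to compound 2 concerns a different site, and nothing isolates the present one. The expectation for compound 4 therefore rests on compound 2 alone, with wide bounds. The expected step is a 1.3-fold lower number from compound 2 to compound 4 (0.12 log units; within the scatter). Compound 4 is estimated at 12000 nM, between 4000 nM and 40000 nM.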

Compound 4, half-maximal inhibitory concentration: > 20000 nM
Compound 4 ended at the assay's limit; the forecaster's own chance of this, stated with the estimate: 10%; at least 1.6-fold (0.22 log units) between middle value and limit.
By their numbers in this assay, from the lowest: compound 3; then compounds 2 and 1 (each within the scatter of the next). At a limit, above all of these: compound 4.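

In this assay compound 4 stands at a limit of the assay, > 20000 nM, not at a number. For the compounds shown here, the only step at this position, furan-2-yl in place of 1-benzofuran-2-yl, gives an at least 1.2-fold higher number from compound 2 to compound 4 (0.10 log units; that floor lies within the scatter), so the change brings no gain in this assay, while the floor of the step does not establish a loss. The reading of this step is bounded by one thing: the limit of > 20000 nM in this assay, at which 1 of the 4 values shown sits. Open, going by these compounds, is how a phenyl ring or an aminomethyl group on this aromatic carbon would read, and how far past the limit compound 4 lies.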